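A few compounds are considered here, and "the series" means these few. Any claim that something is new, unique, unknown or untested is made for them only; others in the source may bear on it.

In a functional assay on UO-31 cells (Homo sapiens) for inhibition, read by sulforhodamine B assay, with a stated time of 48 h (a higher number here means a weaker inhibitor of growth, a lower number a stronger inhibitor of growth), compound 1 `N#C/C(=C\N1CCN(C(=O)c2ccco2)C1=S)C(=O)Nc1ccc(Cl)cc1` gives 12000 nM, and compound 2 `N#C/C(=C\N1CCN(C(=O)c2ccco2)C1=S)C(N)=O` gives 23500 nM. Compound 2 thus holds the higher of the two numbers, but the step of a 2.0-fold higher number from compound 1 to compound 2 (0.29 log units; within the scatter) leaves that gap within the scatter. Compound 3 `N#C/C(=C\N1CCN(C(=O)c2ccco2)C1=S)C(=O)c1ccccc1` differs from compound 2 by phenyl in place of amino on a carbonyl carbon. Going by the values given here, the only measured step bearing on this, a 2.0-fold higher number from compound 1 to compound 2 (0.29 log units; within the scatter), shows that the 4-chlorophenyl group on an amide-type nitrogen in compound 1 goes with a lower number, yet only within the scatter. A step of a 1.6-fold lower number from compound 2 to compound 3 (0.19 log units; within the scatter) in this assay is therefore expected for compound 3, with an estimate of 15000 nM and a range from 6000 nM to 40000 nM.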

Compound 3, concentration for 50% growth inhibition: 10200 nM
Beside the measured number, compound 3's estimate is 1.5-fold (0.17 log units) above it; low and high end bracket the measured number.
By their numbers in this assay, from the lowest: compounds 3, 1 and 2 (each within the scatter of the next, the first and the last beyond it).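

In this assay, going by these compounds alone, the carbonyl carbon tolerates losing its amino group: phenyl in its place gives a 2.3-fold lower number from compound 2 to compound 3 (0.36 log units; beyond the scatter), the first step here beyond the scatter, though a modest one. The nitrogen is not needed to reach this level, since a 1.2-fold lower number from compound 1 to compound 3 (0.07 log units; within the scatter) leaves benzoyl and the (4-chlorophenyl)amino-bearing carbonyl indistinguishable. Nothing available explains either step. The compounds shown leave open how a methyl or a hydroxyl group on this carbonyl carbon would read, and so whether an aromatic ring matters here at all.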